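This account rests on a few compounds, and the source may have more. Where it says the series, first, only, none or still open, it means among the compounds named here.

Measured so far:
- compound 1, `O=C(O)Cc1sc(COc2ccc(Cl)cc2)nc1-c1ccc(Cl)cc1`: in an in vitro functional assay on HEK285-7 cells for antagonist activity at prostaglandin D2 receptor 2 (Homo sapiens), read by BRET and beta-arrestin recruitment (a higher number here means a larger maximal response, a lower number a smaller maximal response), compound 1 gives 50%.
- compound 2, `O=C(O)Cc1sc(C(c2ccc(F)cc2)c2ccc(F)cc2)nc1-c1ccccc1`: in this assay compound 2 gives 80%.

Compound 2 stands highest of the two numbers in this assay; the nearest value, that of compound 1, lies lower by more than the usual scatter. Among the compounds with values here, the two compounds differ in more than one place, so no single step between them is defined; only their two values are known.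

Compound 3, `O=C(O)Cc1sc(C(c2ccc(F)cc2)c2ccc(F)cc2)nc1-c1cc(F)nc(F)c1`, is not yet measured. It differs from compound 2 in one place: 2,6-difluoropyridin-4-yl in place of phenyl on an aromatic carbon. The exchange sits on an aromatic carbon of the shared core, next to the ring nitrogen and next to the ring atom that bears the carboxymethyl group.

Within the data shown here, no measured pair shows what such a swap does to the largest response in this assay. The step from compound 2 to compound 3 is therefore expected to be small, a number 5 percentage points lower from compound 2 to compound 3 (within the scatter), not clearly beyond the scatter in either direction. Compound 3 is expected to give about 75%, within 55% to 95%.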

Compound 3, largest response reached (reported as efficacy), in percent of the reference or control that the assay uses: 80%
Compound 3: the middle estimate sits 5 percentage points below what was measured; the measured number falls inside the stated range.
By their numbers in this assay, from the lowest: compound 1; then compounds 2 and 3 (each within the scatter of the next).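

In this assay, placing 2,6-difluoropyridin-4-yl in place of phenyl on the aromatic carbon next to the ring nitrogen gives no change at the digits printed from compound 2 to compound 3 (within the scatter). This is the only single-place step shown so far, and it establishes that this position accepts a larger ring with a hetero atom and fluorine substituents without a shift in the largest response beyond the scatter. No measurement shown here offers a reason for this result.

Still open, from the compounds shown here alone, is whether a group of another kind at this position, such as an amine or a carboxylic acid, would leave the largest response equally undisturbed. Going by these compounds, it is also open whether the same exchange would read the same way on a compound carrying the other substituent of compound 1 on the shared core.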